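Expected Cytotoxicity of Compound 3 After a Phenyl Ring Swap

This account rests on a few compounds, and the source may have more. Where it says the series, first, only, none or still open, it means among the compounds named here.

Of the compounds shown here, two that share one core have been measured. Compound 1 `O=c1cc(-c2ccccc2O)oc2cc(OCCCCCCCCN3CCCC3)ccc12` gives, in an ADME assay on HepG2 cells (Homo sapiens) for cytotoxicity, read by MTT assay, with a stated time of 48 h, tested at 10 uM (on this read-out higher numbers stand for a stronger effect at the one concentration tested and lower numbers for a weaker effect), a read-out of 60.6%, the highest of the two numbers available. Compound 2 `COc1cc(-c2cc(=O)c3ccc(OCCCCCCCCN4CCCC4)cc3o2)cc(OC)c1OC` gives 41.4%. Within the data shown here, the single step that connects them, a number 19.2 percentage points lower from compound 1 to compound 2 (beyond the scatter), is beyond the scatter of repeated measurements.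

Compound 3 `O=c1cc(-c2ccc(Cl)cc2)oc2cc(OCCCCCCCCN3CCCC3)ccc12` has not yet been measured. It differs from compound 1 in one place: 4-chlorophenyl in place of 2-hydroxyphenyl on an aromatic carbon. Among the measured compounds shown here, no measured step carries exactly this change, but the step from compound 1 to compound 2 alters the same aromatic carbon, exchanging the 2-hydroxyphenyl for another substituted phenyl, and it moved the read-out downward by a modest amount. On that basis a step of similar direction, though smaller, is expected for compound 3, with a real chance of no change beyond the scatter.

Compound 3 is therefore expected to give about 52%, within a range from 30% to 72%, which corresponds to an estimated step of a number 8.6 percentage points lower from compound 1 to compound 3 (within the scatter).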

Compound 3, a percentage reported as inhibition, at one concentration (the size of the read-out at that concentration, not a potency): 25.7%
For compound 3 the middle estimate is 26.3 percentage points above the measured one, outside the stated range (below it).
By their numbers in this assay, from the lowest: compound 3; then compound 2; then compound 1.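

In this assay, exchanging 2-hydroxyphenyl for 4-chlorophenyl on the aromatic carbon next to the ring oxygen gives a number 34.9 percentage points lower from compound 1 to compound 3 (beyond the scatter) and is classed as a large step, so this position can shift the read-out by more than the modest step seen earlier. The step of a number 15.7 percentage points lower from compound 2 to compound 3 (beyond the scatter) shows that the two replacement groups do not behave alike, as 4-chlorophenyl and 3,4,5-trimethoxyphenyl are separated beyond the scatter, and among these three compounds neither replacement matches 2-hydroxyphenyl, with none going against that order. No measurement at hand bears on why the steps take this direction or size.

The single exchange removes the hydroxyl and brings in the chlorine together, and these compounds leave open how much of the step belongs to each change, which an unsubstituted phenyl, a 4-hydroxyphenyl or a 2-chlorophenyl at this carbon could help to separate. They also leave open whether the same order of the three phenyl groups would hold with a morpholine or a piperidine at the end of the chain.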